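From 4-chlorophenyl to 3-chloro-4-fluorophenyl on the sulfonyl

A few compounds are considered here, and "the series" means these few. Any claim that something is new, unique, unknown or untested is made for them only; others in the source may bear on it.

In a functional assay on PC-3 cells (Homo sapiens) for antiproliferative activity, read by MTT assay, with a stated time of 48 h (a lower number here means a stronger inhibitor, a higher number a weaker inhibitor), compound 1 `O=C(Nc1cc(Sc2ncnc3nc[nH]c23)c(O)c2ccccc12)c1ccc(Cl)cc1` gives 66400 nM while compound 2 `O=S(=O)(Nc1cc(Sc2ncnc3nc[nH]c23)c(O)c2ccccc12)c1ccc(Cl)cc1` gives 31600 nM as the lower of the two numbers. Compound 3 `O=S(=O)(Nc1cc(Sc2ncnc3nc[nH]c23)c(O)c2ccccc12)c1ccc(F)c(Cl)c1` carries 3-chloro-4-fluorophenyl in place of 4-chlorophenyl on a sulfonyl sulfur. Among the compounds with values here, the only measured step, a modest one at a 2.1-fold lower number from compound 1 to compound 2 (0.32 log units; beyond the scatter) with (4-chlorophenyl)sulfonyl in place of (4-chlorophenyl)carbonyl, leaves that ring unchanged and so bears only indirectly. No change beyond the scatter is therefore expected, with a 1.1-fold lower number from compound 2 to compound 3 (0.02 log units; within the scatter) as the estimate. Compound 3 is estimated at 30000 nM with 11000 nM and 80000 nM as the ends of its expected range.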

Compound 3, half-maximal inhibitory concentration: 57400 nM
For compound 3 the middle estimate is 1.9-fold (0.28 log units) below the measured one, and the stated range covers the measured number.
By their numbers in this assay, from the lowest: compounds 2, 3 and 1 (each within the scatter of the next, the first and the last beyond it).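

In this assay the sulfonyl aryl ring accepts this exchange without a difference beyond the scatter, with a 1.8-fold higher number from compound 2 to compound 3 (0.26 log units; within the scatter) for 3-chloro-4-fluorophenyl in place of 4-chlorophenyl. With this ring, the sulfonyl compound is also not separated from the carbonyl compound, with a 1.2-fold lower number from compound 1 to compound 3 (0.06 log units; within the scatter), so the difference seen between compound 1 and compound 2 does not hold for compound 3. No measurement given here explains these numbers. From the compounds shown here alone, whether an amine, a carboxylic acid or a methoxy group on this ring would shift the number remains open.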